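Chain lengthening from compound 2 to compound 3

This account rests on a few compounds, and the source may have more. Where it says the series, first, only, none or still open, it means among the compounds named here.

Measured compounds:
compound 1, `CCCCCCCc1ccc(-c2noc(CCCN)n2)cc1`, 52%
compound 2, `CCCCCCCCCc1ccc(-c2noc(CCCN)n2)cc1`, 61%

In an assay on HeLa cells for inhibition of sphingosine-1-phosphate transporter SPNS2 (Mus musculus), read by LC-MS, tested at 2 uM (on this read-out higher numbers stand for more inhibition at the one concentration tested (going by the name of the read-out) and lower numbers for less inhibition), compound 1 gives 52% and compound 2 gives 61%. Within the data shown here, compound 2 stands highest of the two numbers, with compound 1 its only neighbour; the step of a number 9 percentage points higher from compound 1 to compound 2 (within the scatter) is within the scatter, so no order between the two is claimed.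

Compound 3 `CCCCCCCCCCCc1ccc(-c2noc(CCCN)n2)cc1` is not yet measured. Its change from compound 2 is ethyl in place of hydrogen on a saturated chain carbon, nine bonds along the chain from an aromatic carbon. Among the measured compounds shown here, the only measured step that bears on it is a number 9 percentage points higher from compound 1 to compound 2 (within the scatter), which is the same replacement placed seven bonds along the chain from an aromatic carbon; that step was small and within the scatter. A step of similar size, or none beyond the scatter, is therefore expected in this assay for compound 3, that is a number 5 percentage points higher from compound 2 to compound 3 (within the scatter). Compound 3 is estimated at 66%, with a range from 50% to 82%.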

Compound 3, a percentage reported as inhibition, at one concentration (the size of the read-out at that concentration, not a potency): 49%
For compound 3 the middle estimate is 17 percentage points above the measured one; the whole stated range lies above it.
By their numbers in this assay, from the lowest: compounds 3, 1 and 2 (each within the scatter of the next, the first and the last beyond it).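

In this assay, among these compounds, the ethyl replacement placed nine bonds along the chain from an aromatic carbon gives the first step beyond the scatter (a number 12 percentage points lower from compound 2 to compound 3 (beyond the scatter)), though only a modest one, while the same replacement seven bonds along the chain stayed within it (a number 9 percentage points higher from compound 1 to compound 2 (within the scatter)). Taken as a single change, butyl in place of hydrogen seven bonds along the chain gives (a number 3 percentage points lower from compound 1 to compound 3 (within the scatter)), so chain lengthening brings no steady rise across these three compounds. Nothing measured here accounts for the lower number at this chain length.

The compounds shown leave open whether a still longer chain on the same core stays at this level or drops further. They also leave open how a branched chain of similar length, or a carboxylic acid in place of the amine, would read out.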